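Adding a carboxy group to compound 1

The source may hold more compounds than are shown below. What is called first, only, known or untested is meant among the compounds shown, and "the series" means these compounds.

In a functional assay on the whole organism (strain Sprague-Dawley) for inhibition, with Rattus norvegicus as the target, with a stated time of 10 min (a higher number here means that more compound is needed for the effect, a lower number that less compound is needed), compound 1 (`CCOc1ccccc1-c1ncc(C(=O)O)c(=O)[nH]1`) gives 0.5 mg/kg. Compound 2 (`CCC(C)Oc1ccccc1-c1ncc(C(=O)O)c(=O)[nH]1`) gives 0.5 mg/kg, level with compound 1 at the digits reported. Compound 3 (`C[S+]([O-])c1ccccc1-c1ncc(C(=O)O)c(=O)[nH]1`) is recorded only as a limit of the assay, > 5 mg/kg.

Compound 4 (`CCOc1ccc(C(=O)O)cc1-c1ncc(C(=O)O)c(=O)[nH]1`) keeps the ethoxy group of compound 1 and changes the same aromatic ring: carboxy in place of hydrogen on an aromatic carbon. Among the compounds with values here, no measured step places a new group at this carbon, so the evidence is indirect. Lengthening the chain on the oxygen gave no change at the digits printed from compound 1 to compound 2 (within the scatter), which shows that one change was tolerated. Replacing the whole group on the aromatic carbon gave an at least 10-fold higher number from compound 1 to compound 3 (1.00 log units; beyond the scatter) and an at least 10-fold higher number from compound 2 to compound 3 (1.00 log units; beyond the scatter), which shows that the values can also move sharply. With only these steps as a guide, a moderate rise in the number is expected, smaller than the rises seen for compound 3 at > 5 mg/kg. The expected change is a 3.0-fold higher number from compound 1 to compound 4 (0.48 log units; beyond the scatter). For compound 4 the estimate is 1.5 mg/kg, with an expected range from 0.3 mg/kg to 8 mg/kg.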

Compound 4, dose for 50% inhibition: 25 mg/kg
Compound 4: the middle estimate sits 17-fold (1.22 log units) below what was measured, and the stated range ends below it.
By their numbers in this assay, from the lowest: compounds 1 and 2 (each within the scatter of the next); then compound 4.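

In this assay, placing a carboxy group on the aromatic carbon para to the ethoxy group gives a 50-fold higher number from compound 1 to compound 4 (1.70 log units; beyond the scatter). Within the data shown here, the earlier compounds varied only the group on the other aromatic carbon, so this is the first sign that the whole-animal read-out is also highly sensitive to a change at this position, with the ethoxy group left in place. Unlike compound 3, whose entry is a limit of the assay and not a number, compound 4 has a measured value: the limit of > 5 mg/kg in this assay, at which 1 of the 4 values shown sits.

The compounds shown leave open whether this rise belongs to the carboxy group itself or would follow any new group at this carbon, such as a methyl, a chlorine or a methyl ester. They also leave open how a carboxy group would fare at the other carbons of this ring.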